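Swapping the Aromatic Ring on the Amide Nitrogen

The source may report more compounds than this note shows. Statements on the series, on what has been measured and on what is new or still open speak of the compounds shown alone.

compound 1 `Cc1ccc(OCC(=O)N(Cc2cccs2)c2nccn2C)cc1` — 1790 nM
compound 2 `CCN(Cc1cccs1)C(=O)COc1ccc(OC)cc1` — 120 nM

Among the measured compounds shown here, in an assay on HEK293 cells for agonist activity at transient receptor potential cation channel subfamily M member 8 (Homo sapiens), read by fluorescence and calcium flux, with a stated time of 15 min (a lower number here means that less compound is needed, a higher number that more compound is needed for the effect), compound 1 gives 1790 nM, the higher of the two numbers measured so far. Compound 2 gives 120 nM, a gap from compound 1 that lies beyond the scatter. Compound 3 `Cc1ccc(OCC(=O)N(Cc2cccs2)c2cnccn2)cc1` differs from compound 1 in one place: pyrazin-2-yl in place of 1-methyl-1H-imidazol-2-yl on an amide-type nitrogen. For the measured compounds named here, no measured pair shows what this exchange does, so the expectation rests on compound 1 alone. The step expected in this assay is a 1.2-fold lower number from compound 1 to compound 3 (0.08 log units; within the scatter), a modest one with no firm direction. Compound 3 is therefore expected to give 1500 nM, within a range of 400 nM to 6000 nM.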

Compound 3, half-maximal effective concentration: 1240 nM
Beside the measured number, compound 3's estimate is 1.2-fold (0.08 log units) above it, within the range that was stated.
By their numbers in this assay, from the lowest: compound 2; then compounds 3 and 1 (each within the scatter of the next).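

Exchanging 1-methyl-1H-imidazol-2-yl for pyrazin-2-yl on the amide-type nitrogen gives a 1.4-fold lower number from compound 1 to compound 3 (0.16 log units; within the scatter) in this assay. At this position, then, a six-membered aromatic ring with 2 hetero atoms and a five-membered one with 2 hetero atoms cannot be told apart by this read-out. Nothing available explains this result. Still open, as far as these compounds go, is how a plain phenyl ring or a saturated chain such as propyl would read on this nitrogen. Also open, from the compounds shown here alone, is whether this exchange would give a similar step on another core.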